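Thiosemicarbazone series: swapping the aryl substituent on the imine carbon

The compounds below may be only part of what the source reports. "The series", "measured", "known", "first", "only" and "open" are said of these compounds alone.

Compound 1 `CC1=CC[C@@H]([C@@](C)(O)CCCC(C)(C)NC(=S)N/N=C\c2ccc(C)cc2)CC1` and compound 2 `CC1=CC[C@@H]([C@@](C)(O)CCCC(C)(C)NC(=S)N/N=C\c2ccc([N+](=O)[O-])cc2)CC1` share one core and differ only in the group on the aromatic ring. In a functional assay on K562 cells (Homo sapiens) for cytotoxicity, read by sulforhodamine B assay (on this read-out higher numbers stand for weaker inhibition of growth and lower numbers for stronger inhibition of growth), compound 1 gives 140 nM, and compound 2 gives 4220 nM. For the measured compounds named here, the single measured step, a 30-fold higher number from compound 1 to compound 2 (1.48 log units; beyond the scatter), leaves compound 2 with the highest number of the two.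

Compound 3 `CC1=CC[C@@H]([C@@](C)(O)CCCC(C)(C)NC(=S)N/N=C\c2ccccc2Cl)CC1` is not yet measured. Relative to compound 2 the change is 2-chlorophenyl in place of 4-nitrophenyl on a carbon with a double bond to nitrogen. Going by the values given here, no measured step covers this exact exchange; the only step that bears on it is the one from compound 1 to compound 2, which was large, and compound 3 carries neither of the two groups of that step. The expectation for compound 3 is therefore a number somewhere between those of compound 1 and compound 2, expected as a 7.0-fold lower number from compound 2 to compound 3 (0.85 log units; beyond the scatter) in this assay. The estimate for compound 3 is 600 nM, in the range 150 nM to 3000 nM.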

Compound 3, concentration for 50% growth inhibition: 150 nM
The estimate for compound 3 lay 4.0-fold (0.60 log units) above the measured number; measured number inside the range.
By their numbers in this assay, from the lowest: compounds 1 and 3 (each within the scatter of the next); then compound 2.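

In this assay, replacing 4-nitrophenyl with 2-chlorophenyl on the carbon with a double bond to nitrogen gives a 28-fold lower number from compound 2 to compound 3 (1.45 log units; beyond the scatter), so this place tolerates a second aryl group that does not share the high number of compound 2. The exchange of 4-methylphenyl for 2-chlorophenyl gives a 1.1-fold higher number from compound 1 to compound 3 (0.03 log units; within the scatter), which means that these two aryl groups cannot be told apart in this assay, and among the three compounds only compound 2 stands apart. Nothing measured here accounts for that difference.

The compounds shown leave open whether the 4-nitrophenyl result is a lone case or part of a wider trend, as no other group on the aromatic ring, such as an amine or a carboxylic acid, appears among them. For the compounds shown here, they also do not separate the identity of a ring substituent from its place, as no two compounds carry the same substituent at different places.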